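From Fluoro to Hydrogen on the Aromatic Ring

The source may report more compounds than this note shows. Statements on the series, on what has been measured and on what is new or still open speak of the compounds shown alone.

Compound 1 `CCC(C(=O)N1CCN(c2ccccc2F)CC1)N1C(=O)CCC1=O` gives 100% in a functional assay on the whole organism (strain Swiss) with Mus musculus as the target, in the maximal electroshock model, with a stated time of 0.5 h, at a dose of 300 mg/kg by the intraperitoneal route; on this read-out lower numbers stand for a weaker effect and higher numbers for a stronger effect at the one dose given. Compound 2 `CCC(C(=O)N1CCN(c2ccccc2C(F)(F)F)CC1)N1C(=O)CCC1=O` gives 25% in this assay, and compound 3 `CC(C(=O)N1CCN(c2ccc(F)cc2)CC1)N1C(=O)CCC1=O` gives 50% in this assay. Compound 3 therefore stands second highest of the three numbers: compound 2 lies nearer to it and below it, compound 1 further away and above it, both gaps beyond the scatter.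

Compound 4 `CC(C(=O)N1CCN(c2ccccc2)CC1)N1C(=O)CCC1=O` differs from compound 3 in one place: hydrogen in place of fluoro on an aromatic carbon. Among the compounds with values here, the single measured step, a number 75 percentage points lower from compound 1 to compound 2 (beyond the scatter), concerns a different exchange at a different place in the shared core and so bears on this step only loosely; it shows that a change on the aromatic ring can move the read-out a great deal, but no measured step trades fluoro for hydrogen. Within the data shown here, with no close precedent, the expectation is a step in this assay that does not exceed the scatter, in either direction.

Compound 4 is thus expected to give 50%, with a range from 25% to 75%. The expected step of no change at the digits printed from compound 3 to compound 4 (within the scatter) is estimated to stay within the scatter.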

Compound 4, a percentage reported as activity, at one dose (the size of the read-out at that dose, not a potency): 50%
For compound 4 middle estimate and measured number coincide at the digits printed, and the stated range covers the measured number.
By their numbers in this assay, from the lowest: compound 2; then compounds 3 and 4 (each within the scatter of the next); then compound 1.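

Within the data shown here, the step of no change at the digits printed from compound 3 to compound 4 (within the scatter) in this assay is the first measured exchange at this position, and 4-fluorophenyl to phenyl leaves the read-out within the scatter. Fluoro on this aromatic carbon, para to a large group, is therefore not required for the effect seen at this one dose, a point the earlier step of a number 75 percentage points lower from compound 1 to compound 2 (beyond the scatter), a different exchange at a different place, could not settle. The data at hand offer no explanation for this result.

Going by these compounds, it remains open whether a methoxy group, an amine or a carboxylic acid on this aromatic carbon would also stay within the scatter of hydrogen and fluoro. Also open, on these data alone, is whether hydrogen in place of fluoro would give the same outcome on the core of compound 1, where fluoro sits at another place on the ring.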